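Extending the Alkyl Chain: What to Expect of Compound 4

A few compounds are considered here, and "the series" means these few. Any claim that something is new, unique, unknown or untested is made for them only; others in the source may bear on it.

Measured in a functional assay on A549 cells (Homo sapiens) for cytotoxicity, read by MTT assay, with a stated time of 72 h; a lower number here means a stronger inhibitor, a higher number a weaker inhibitor:
compound 1, `CC/C(=C\c1cc(OC)c(OC)c(OC)c1)C(=O)N1CCC=CC1=O`: 18000 nM
compound 2, `CC/C(=C\c1cc(OC)c(OC)c(OC)c1)C(=O)N1CCC=C(Cl)C1=O`: 4060 nM
compound 3, `COc1cc(/C=C(\C)C(=O)N2CCC=CC2=O)cc(OC)c1OC`: 24000 nM

Compound 3 and compound 1 differ by methyl in place of hydrogen on a saturated chain carbon bound to a double-bonded chain carbon; in this assay the step is a 1.3-fold lower number from compound 3 to compound 1 (0.12 log units; within the scatter). Compound 1 and compound 2 differ by chloro in place of hydrogen on a double-bonded ring carbon, and here a 4.4-fold lower number from compound 1 to compound 2 (0.65 log units; beyond the scatter). Compound 2 therefore gives the lowest of the three numbers, and the other two lie beyond the scatter from it.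

Compound 4, `CCC/C(=C\c1cc(OC)c(OC)c(OC)c1)C(=O)N1CCC=C(Cl)C1=O`, has not been measured. It differs from compound 2 by methyl in place of hydrogen on a saturated chain carbon, two bonds along the chain from a double-bonded chain carbon. Among the compounds with values here, this is the same kind of change as the one from compound 3 to compound 1, but the place is not identical: in the earlier pair the saturated chain carbon is bound to a double-bonded chain carbon, whereas in compound 4 it lies two bonds along the chain from a double-bonded chain carbon. The difference between the cores of compound 2 and compound 3 is not broken down here.

Because the earlier step of a 1.3-fold lower number from compound 3 to compound 1 (0.12 log units; within the scatter) lies within the scatter, the step to compound 4 is expected to be small as well, about a 1.2-fold lower number from compound 2 to compound 4 (0.06 log units; within the scatter). Compound 4 is estimated at 3500 nM in this assay, with a likely range from 1500 nM to 9000 nM.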

Compound 4, half-maximal inhibitory concentration: 3810 nM
Compound 4: middle estimate off by 1.1-fold (0.04 log units), on the low side, and the stated range covers the measured number.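

In this assay, methyl in place of hydrogen on the saturated chain carbon gives a 1.1-fold lower number from compound 2 to compound 4 (0.03 log units; within the scatter), and this step reads much like the earlier one on the other core: the same change on two cores in this assay, a 1.3-fold lower number (0.12 log units; within the scatter) from compound 3 to compound 1 and a 1.1-fold lower number (0.03 log units; within the scatter) from compound 2 to compound 4, 1.3-fold (0.10 log units) apart, within the scatter of two such steps.
The change, which reads as methyl to ethyl on the first pair and ethyl to propyl on the second, thus stays within the scatter on both cores, whereas a 4.4-fold lower number from compound 1 to compound 2 (0.65 log units; beyond the scatter) is the single-place step shown here that lies beyond it. Within the data shown here, this agreement rests on only two pairs in one assay, with the change at places that are not identical, so it does not show that the step would stay this small on other cores or at other places, and it gives no reason for its size.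

The compounds shown leave open what a chain longer than propyl, a branched chain, or a chain ending in an amine or a carboxylic acid would give at this place. They also leave open whether bromo or fluoro in place of the chloro would keep the step seen with chloro, and how the chain change would read on such cores.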